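The source may hold more compounds than are shown below. What is called first, only, known or untested is meant among the compounds shown, and "the series" means these compounds.

Measured so far in a physicochemical assay for lipophilicity (a lower number here means a more polar compound, a higher number a more lipophilic compound), are these two compounds:

- compound 1 `COCCCNCc1cc([C@]2(C)CCSC(N)=N2)c(F)cc1F` with -0.5
- compound 2 `COC[C@@H](C)NCc1cc([C@]2(C)CCSC(N)=N2)c(F)cc1F` with -0.3

Compound 2 lies within the usual scatter of compound 1, so the two cannot be told apart on these numbers. Compound 3 `C[C@@]1(c2cc(CNCCC(F)(F)F)c(F)cc2F)CCSC(N)=N1` has not yet been measured. It carries 3,3,3-trifluoropropyl in place of 1-(methoxymethyl)ethyl on an amine nitrogen. Going by the values given here, only one measured step bears on this change, a number 0.20 log units higher from compound 1 to compound 2 (within the scatter) and it swaps one oxygen-bearing chain for another. Among the compounds with values here, it therefore says little about losing the oxygen altogether, and no measured compound has a fluorinated chain. The size is thus a judgement with wide uncertainty, but in this assay a clear rise beyond the scatter is expected. The expected step is a number 1.20 log units higher from compound 2 to compound 3 (beyond the scatter) in size. For compound 3 the estimated value is 0.9 with a likely range from 0.2 to 1.6 on this scale.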

Compound 3, distribution coefficient: 0.5
For compound 3 the middle estimate is 0.40 log units above the measured one; the measured number falls inside the stated range.
By their numbers in this assay, from the lowest: compounds 1 and 2 (each within the scatter of the next); then compound 3.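

In this assay, the chain on this amine nitrogen now gives a step that stands clear of the scatter: 3,3,3-trifluoropropyl in place of 1-(methoxymethyl)ethyl gives (a number 0.80 log units higher from compound 2 to compound 3 (beyond the scatter)). Trifluoromethyl in place of methoxymethyl on a saturated chain carbon, two bonds along the chain from an amine nitrogen, reads the same way (a number 1.00 log units higher from compound 1 to compound 3 (beyond the scatter)). Going by these compounds alone, the two oxygen-bearing chains could not be told apart, so this is the first sign that the chain at this position can move the number, though nothing at hand gives a reason for the rise.

Left open is whether the rise follows the loss of the oxygen or the arrival of the fluorine atoms, which a plain propyl chain on the same nitrogen would separate. Also open, on these data alone, is where in this assay a chain ending in a carboxylic acid or a second amine would fall.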